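The source may hold more compounds than are shown below. What is called first, only, known or untested is meant among the compounds shown, and "the series" means these compounds.

Of the compounds shown here, three sharing one core have been tested in an ADME assay on J774 cells (Mus musculus) for cytotoxicity (a lower number here means that less compound is needed, a higher number that more compound is needed for the effect), so far. Compound 1 (`C=C(CCCCCCC)c1c(C)[nH]c2ccccc2c1=O`) gives a half-maximal effective concentration of 89100 nM in this test. Compound 2 (`COc1cccc2[nH]c(C)c(Cc3ccccc3)c(=O)c12`) gives 11200 nM on the same read-out. Compound 3 (`COc1cc2[nH]c(C)c(C3CCCCC3)c(=O)c2cc1Cl`) has no exact number, only the limit > 32700 nM as its result.

Compound 4 (`CCCCC#Cc1c(C)[nH]c2cc(OC)c(Cl)cc2c1=O`) has hex-1-yn-1-yl in place of the cyclohexyl of compound 3 on an aromatic carbon, and the rest of the structure is unchanged: hex-1-yn-1-yl in place of cyclohexyl on an aromatic carbon is the whole difference. Within the data shown here, no pair of measured compounds differs in one place alone, so the data offer no direct measure of this exchange. Compound 1 also carries an open carbon chain and gives 89100 nM in this assay as its result, which gives no reason to expect a sharp fall in the number for compound 4. Only a modest change is therefore expected, with no firm direction, and the estimated move is a step that the limit leaves unreadable from compound 3 to compound 4 on this reasoning. Compound 4 is expected at about 40000 nM in this assay as a central estimate. The estimated range for compound 4 runs from 14000 nM to 100000 nM in all, and the test may again return only a limit.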

Compound 4, half-maximal effective concentration in the J774 assay: 15000 nM
Compound 4: the middle estimate sits 2.7-fold (0.43 log units) above what was measured; the measured number falls inside the stated range.
By their numbers in the J774 assay, from the lowest: compounds 2 and 4 (each within the scatter of the next); then compound 1.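

Among these compounds, on an aromatic carbon of the six-membered aromatic ring with 1 nitrogen, hex-1-yn-1-yl in place of cyclohexyl gives, in the J774 assay, an at least 2.1-fold lower number from compound 3 to compound 4 (0.33 log units; beyond the scatter), the first measure of a change at this one place, and it shows that the number responds to the group here even though the count of 6 heavy atoms stays the same. Compound 3 has only a limit of the assay as its result, so this step sets a minimum size and not an exact one: the limit of > 32700 nM in the J774 assay, at which 1 of the 4 values shown sits. In a physicochemical assay for lipophilicity, at pH 7.4 (on this read-out higher numbers stand for higher lipophilicity and lower numbers for lower lipophilicity), compound 3 gives 3.04 and compound 4 gives 2.45. In the physicochemical assay the same exchange goes with lower lipophilicity, so both read-outs fall together in this single pair: the measured distribution coefficient of compound 3, 3.04, and of compound 4, 2.45, a number 0.59 log units lower (beyond the scatter)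

From the compounds shown here alone, what remains open is whether the lower number in the J774 assay belongs to the triple bond, to the loss of the ring or to the lower lipophilicity, and a saturated hexyl chain on the same carbon would help to tell these apart. Going by these compounds, it is also open how far the number would move with an amine or a carboxylic acid at the end of the chain, or with a longer chain.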